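Amine variation on a thiocarbonyl carbon

The source may hold more compounds than are shown below. What is called first, only, known or untested is meant among the compounds shown, and "the series" means these compounds.

Measured so far, in a functional assay on MDA-MB-435S cells (Homo sapiens) for antiproliferative activity, read by MTT assay, with a stated time of 72 h; on this read-out higher numbers stand for weaker inhibition and lower numbers for stronger inhibition:
compound 1, `O=c1c(CSC(=S)N2CCCC2)coc2ccccc12`: 3800 nM
compound 2, `O=c1c(CSC(=S)N2CCOCC2)coc2ccccc12`: 3900 nM

For the measured compounds named here, compound 2 holds the higher of the two numbers, but the only measured step, a 1.0-fold higher number from compound 1 to compound 2 (0.01 log units; within the scatter), stays within the scatter, so the two amines behave alike here. Compound 3, `CC(C)N(C(=S)SCc1coc2ccccc2c1=O)C(C)C`, carries the change (diisopropylamino in place of morpholin-4-yl on a thiocarbonyl carbon). Going by the values given here, the one step that bears on it is the amine swap just noted, which moved nothing beyond the scatter; a further amine swap at the same place is therefore expected to give no step beyond the scatter in this assay. For compound 3 the estimate is 4000 nM, with a range of 2000 nM to 8000 nM. That estimate means an expected 1.0-fold higher number from compound 2 to compound 3 (0.01 log units; within the scatter).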

Compound 3, half-maximal inhibitory concentration: 7900 nM
Compound 3: the middle estimate sits 2.0-fold (0.30 log units) below what was measured; the range from low to high includes it.
By their numbers in this assay, from the lowest: compounds 1 and 2 (each within the scatter of the next); then compound 3.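

In this assay the amine on a thiocarbonyl carbon turns out not to be silent: diisopropylamino gives a 2.0-fold higher number from compound 2 to compound 3 (0.31 log units; beyond the scatter) and a 2.1-fold higher number from compound 1 to compound 3 (0.32 log units; beyond the scatter) while the two ring amines, pyrrolidin-1-yl and morpholin-4-yl, stay within the scatter of each other. Both steps are modest, and both run towards weaker inhibition. Nothing available accounts for these steps.

Still open, as far as these compounds go, is whether a smaller open-chain amine such as dimethylamino or diethylamino sides with the ring amines or with diisopropylamino. From the compounds shown here alone, the place of a piperidin-1-yl ring is equally open.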